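Difluorobenzyl in Place of Methylbenzyl on a Shared Core

A few compounds are considered here, and "the series" means these few. Any claim that something is new, unique, unknown or untested is made for them only; others in the source may bear on it.

Three compounds share one core and differ only in the aryl group carried by the saturated chain carbon bound to the sulfur. Compound 1 `O=[N+]([O-])c1cccc(CSc2nnc(-c3ccc4c(c3)OCCO4)n2-c2ccccc2)c1` gives 7590 nM in a functional assay on SW 1116 cells (Homo sapiens) for antiproliferative activity, read by MTT assay, with a stated time of 24 h; on this read-out lower numbers stand for stronger inhibition and higher numbers for weaker inhibition. Compound 2 `Clc1cccc(CSc2nnc(-c3ccc4c(c3)OCCO4)n2-c2ccccc2)c1` gives 10600 nM in this assay, and compound 3 `Cc1ccc(CSc2nnc(-c3ccc4c(c3)OCCO4)n2-c2ccccc2)cc1` gives 16200 nM. Compound 3 thus has the highest number of the three: a 1.5-fold higher number from compound 2 to compound 3 (0.18 log units; within the scatter) is within the scatter, while a 2.1-fold higher number from compound 1 to compound 3 (0.33 log units; beyond the scatter) lies just beyond it. The untested compound 4 `Fc1ccc(CSc2nnc(-c3ccc4c(c3)OCCO4)n2-c2ccccc2)c(F)c1` carries 2,4-difluorophenyl in place of 4-methylphenyl on a saturated chain carbon bound to a sulfur. Among the measured compounds shown here, the steps that bear on this change are the two that also exchange the aryl group at that position: a 1.5-fold higher number from compound 2 to compound 3 (0.18 log units; within the scatter), which stayed within the scatter, and a 2.1-fold higher number from compound 1 to compound 3 (0.33 log units; beyond the scatter), which was only modest. A halogen-bearing ring in place of the methyl-bearing one is therefore expected to give a step of a 1.5-fold lower number from compound 3 to compound 4 (0.17 log units; within the scatter) in this assay, toward a lower number but probably not beyond the scatter. Compound 4 is estimated at 11000 nM, with a range from 5000 nM to 25000 nM.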

Compound 4, half-maximal inhibitory concentration: 7830 nM
For compound 4 the middle estimate is 1.4-fold (0.15 log units) above the measured one; the measured number falls inside the stated range.
By their numbers in this assay, from the lowest: compounds 1, 4, 2 and 3 (each within the scatter of the next, the first and the last beyond it).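

The exchange of 4-methylphenyl for 2,4-difluorophenyl on a saturated chain carbon bound to a sulfur gave, in this assay, a 2.1-fold lower number from compound 3 to compound 4 (0.32 log units; beyond the scatter), a modest step that ran toward a lower number. The difluorinated ring is not separated from the other two rings, since a 1.4-fold lower number from compound 2 to compound 4 (0.13 log units; within the scatter) and a 1.0-fold higher number from compound 1 to compound 4 (0.01 log units; within the scatter) both stay within the scatter. Compound 3 thus stands apart from compound 1 and compound 4, but compound 2 goes against any clean split. Compound 2 lies within the scatter of all three others. Nothing available gives a reason for these steps. The compounds shown leave open whether a ring with a single fluorine would behave like compound 4. They also leave open whether an amine or a carboxylic acid on the ring, or a longer chain between the sulfur and the ring, would move the number further.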